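Butyl urea to ethyl carbamate on a shared core

The compounds below may be only part of what the source reports. "The series", "measured", "known", "first", "only" and "open" are said of these compounds alone.

Compound 1, `CCCCNC(=O)Nc1cccc2c1CN(C)CC2c1ccccc1`, gives 69 mg/kg in a functional assay on the whole organism for inhibition of sodium-dependent dopamine transporter (Mus musculus); on this read-out lower numbers stand for an effect already at smaller amounts and higher numbers for an effect only at larger amounts of compound.
Compound 2, `CCCCNC(=O)Nc1cccc2c1CN(C)CC2c1ccc(Cl)cc1`, gives about 120 mg/kg in this assay.
Compound 3, `CCCCNC(=O)Nc1cccc2c1CN(C)CC2c1ccc(C)cc1`, gives > 100 mg/kg in this assay, which is a limit of the assay and not a number.

Compound 2 and compound 1 stand within the usual scatter of each other, since the step of a 1.7-fold higher number from compound 1 to compound 2 (0.24 log units; within the scatter) is within the scatter. For compound 3 the assay reports only (the limit of > 100 mg/kg in this assay, at which 1 of the 3 values shown sits). The step of an at least 1.4-fold higher number from compound 1 to compound 3 (0.16 log units; that floor lies within the scatter) therefore has a floor that itself lies within the scatter, and the step that the limit leaves unreadable from compound 2 to compound 3 cannot be read at all.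

Compound 4, `CCOC(=O)Nc1cccc2c1CN(C)CC2c1ccc(Cl)cc1`, differs from compound 2 by ethoxy in place of butylamino on a carbonyl carbon. Within the data shown here, all three measured steps change a substituent on an aromatic carbon; none touches the carbonyl carbon where this change sits, so no measured step gives a size or a direction for it. The step of no change at the digits printed from compound 2 to compound 4 (within the scatter) is therefore expected to be none beyond the scatter, with wide uncertainty. Compound 4 is estimated at 120 mg/kg in this assay, expected to fall between 40 mg/kg and 360 mg/kg.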

Compound 4, dose for half-maximal effect: 21 mg/kg
Beside the measured number, compound 4's estimate is 5.7-fold (0.76 log units) above it; the measured number lies below the stated range.
By their numbers in this assay, from the lowest: compound 4; then compounds 1 and 2 (each within the scatter of the next).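

On the carbonyl carbon, ethoxy in place of butylamino gives a 5.7-fold lower number from compound 2 to compound 4 (0.76 log units; beyond the scatter) in this assay. This is the first step among the compounds shown that is printed as beyond the scatter, whereas the readable changes on an aromatic carbon stayed within it or left only a floor within it, so this position responds to a change where those steps did not. Nothing shown accounts for the size of this step.

The change replaces the linking nitrogen with oxygen and shortens the chain in one move, so a compound with ethylamino or butoxy on the same carbonyl carbon would be needed to tell these two parts apart. From the compounds shown here alone, whether ethoxy gives a similar step with chloro replaced by hydrogen or methyl on the aromatic carbon also remains open.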